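Swapping Benzylsulfanyl for Ethylamino on the Shared Core

This account rests on a few compounds, and the source may have more. Where it says the series, first, only, none or still open, it means among the compounds named here.

Among the compounds with values here, compound 2 `Nc1nc(SCc2ccccc2)nc2c1nc(O)n2Cc1ccccc1` gives 0.1 uM in a functional assay (spleen, spleen) for activation, with Mus musculus as the target (on this read-out lower numbers stand for an effect already at smaller amounts and higher numbers for an effect only at larger amounts of compound), the lowest of the two numbers measured so far, whereas compound 1 `Cc1nc(N)c2nc(O)n(Cc3ccccc3)c2n1` gives 1 uM. Within the data shown here, the one measured step, a 10-fold lower number from compound 1 to compound 2 (1.00 log units; beyond the scatter), came with benzylsulfanyl in place of methyl on an aromatic carbon. Compound 3 `CCNc1nc(N)c2nc(O)n(Cc3ccccc3)c2n1` differs from compound 2 by ethylamino in place of benzylsulfanyl on an aromatic carbon. Among the measured compounds shown here, no step of exactly this kind has been measured; since the benzylsulfanyl of compound 2 went with the lower number in a 10-fold lower number from compound 1 to compound 2 (1.00 log units; beyond the scatter), its replacement by ethylamino is expected to bring a 10-fold higher number from compound 2 to compound 3 (1.00 log units; beyond the scatter). Compound 3 is therefore estimated at 1 uM, within 0.3 uM to 3 uM.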

Compound 3, minimum effective concentration: 1 uM
Beside the measured number, compound 3's estimate shows no gap at the digits printed; measured number inside the range.
By their numbers in this assay, from the lowest: compound 2; then compounds 1 and 3 (each within the scatter of the next).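

At this position, between two ring nitrogen atoms, ethylamino does not keep what benzylsulfanyl showed: in this assay the swap brings a 10-fold higher number from compound 2 to compound 3 (1.00 log units; beyond the scatter) and ethylamino in place of methyl brings no change at the digits printed from compound 1 to compound 3 (within the scatter) here. Among these three compounds, only the benzylsulfanyl of compound 2 stands apart, while methyl and ethylamino sit together. Nothing given here accounts for this. Going by these compounds, whether the sulfur or the benzyl ring carries the difference stays open. Benzylamino, benzyloxy or a butylsulfanyl chain at this position would begin to separate the two.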